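The source may report more compounds than this note shows. Statements on the series, on what has been measured and on what is new or still open speak of the compounds shown alone.

Series measured in a functional assay on NCI-H520 cells (Homo sapiens) for cytotoxicity; a higher number here means a weaker inhibitor of growth, a lower number a stronger inhibitor of growth:

- compound 1 `COc1ccc(C2=C(c3ccc(SC)cc3)CC3CCCN3C2=O)cc1O`: 6000 nM
- compound 2 `COc1ccc(C2=C(c3ccc(SC)cc3)CC3CCCN3C2=O)cc1C`: 100 nM
- compound 3 `CSc1ccc(C2=C(c3ccc(Br)cc3)C(=O)N3CCCC3C2)cc1`: 7000 nM

Compound 3 belongs to the high-number pair of the set. The two members of that pair differ only by scatter: a 1.2-fold higher number from compound 1 to compound 3 (0.07 log units; within the scatter). Compound 2 stands well apart, as shown by a 70-fold higher number from compound 2 to compound 3 (1.85 log units; beyond the scatter).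

Compound 4 `CSc1ccc(C2=C(c3ccc(SC)cc3)C(=O)N3CCCC3C2)cc1` is the next entry. It has methylsulfanyl in place of bromo on an aromatic carbon, para to a large group (methylsulfanyl in place of bromo on an aromatic carbon). This turns 4-bromophenyl into 4-(methylsulfanyl)phenyl.

Going by the values given here, no measured pair makes this exact swap, so the evidence is indirect. The aryl group on the double-bonded ring carbon clearly matters in compound 2, given a 70-fold higher number from compound 2 to compound 3 (1.85 log units; beyond the scatter). A single change on that aryl group can also be large, as a 60-fold lower number from compound 1 to compound 2 (1.78 log units; beyond the scatter) shows. However, replacing that group does not always move the number, as a 1.2-fold higher number from compound 1 to compound 3 (0.07 log units; within the scatter) shows.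

A moderate move to a lower number in this assay is therefore expected, although no change beyond the scatter remains possible. The expected change is a 2.8-fold lower number from compound 3 to compound 4 (0.45 log units; beyond the scatter). The estimate for compound 4 is 2500 nM, with an expected range of 400 nM to 10000 nM.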

Compound 4, concentration for 50% growth inhibition: 15000 nM
The estimate for compound 4 lay 6.0-fold (0.78 log units) below the measured number; measured number above the stated range.
By their numbers in this assay, from the lowest: compound 2; then compounds 1 and 3 (each within the scatter of the next); then compound 4.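

Going by these compounds alone, replacing bromo with methylsulfanyl on this aromatic carbon, para to a large group, gives the first direct reading at this position in this assay: a 2.1-fold higher number from compound 3 to compound 4 (0.33 log units; beyond the scatter). The change is modest, but it shows that the position responds to a small substituent swap and that methylsulfanyl gives the higher number of the two groups. Within the data shown here, with 4-(methylsulfanyl)phenyl on the double-bonded ring carbon, the series shows a 2.5-fold higher number from compound 1 to compound 4 (0.40 log units; beyond the scatter) and a 150-fold higher number from compound 2 to compound 4 (2.18 log units; beyond the scatter), so this compound is the weakest of the set and the 4-methoxy-3-methylphenyl group of compound 2 remains the only aryl group here linked to a low number. Nothing available accounts for the direction of the bromo to methylsulfanyl step.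

The compounds shown leave open whether an amine, a carboxylic acid or a longer chain such as ethylsulfanyl on the same aromatic carbon would shift the number further or bring it down. They also leave open how the 4-methoxy-3-methylphenyl group would behave alongside a bromo in place of methylsulfanyl on the other aryl group.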